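A few compounds are considered here, and "the series" means these few. Any claim that something is new, unique, unknown or untested is made for them only; others in the source may bear on it.

Working notes on the series. Toxicity is followed in a toxicity assay on the whole organism (strain Icem-CET (SPF Caw)) for cytotoxicity, with Mus musculus as the target; a lower number here means that less compound is needed, a higher number that more compound is needed for the effect. Compound 1 `C=CCNC(=O)/C(C)=C(/C)c1ccc(Cl)cc1` gives 400 mg/kg in this assay. Among the compounds with values here, compound 2 `C=CCNC(=O)/C(C)=C(\C)c1ccc(C)cc1` gives 150 mg/kg in this assay, the lowest of the two numbers known so far, with compound 1 the nearer neighbour and beyond the scatter. Compound 3 `C=CCNC(=O)/C(C)=C(\C)c1ccc(Cl)cc1` is not yet measured; it differs from compound 2 by chloro in place of methyl on an aromatic carbon. Within the data shown here, no measured pair shows this change directly. Because compound 1 also bears chloro and gives 400 mg/kg, the step from compound 2 to compound 3 is expected to be a 2.0-fold higher number from compound 2 to compound 3 (0.30 log units; within the scatter), a rise. Compound 3 is estimated at 300 mg/kg, within 150 mg/kg to 600 mg/kg.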

Compound 3, dose for half-maximal effect: 70 mg/kg
Beside the measured number, compound 3's estimate is 4.3-fold (0.63 log units) above it; the whole stated range lies above it.
By their numbers in this assay, from the lowest: compound 3; then compound 2; then compound 1.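

On the double bond drawn E, chloro in place of methyl on an aromatic carbon, para to a large group, moves the result in this assay down: a 2.1-fold lower number from compound 2 to compound 3 (0.33 log units; beyond the scatter). Chloro alone does not set the number, as the same substituent gives a 5.7-fold lower number from compound 1 to compound 3 (0.76 log units; beyond the scatter). That second step can be assigned to configuration alone: the fact that compounds 1 and 3 differ only in the configuration as drawn

Open, from the compounds shown here alone, is whether chloro in place of methyl gives a similar step on the double bond drawn Z. Also open is how an amine, a carboxylic acid or a longer chain at this position would read in this assay.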